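The compounds below may be only part of what the source reports. "The series", "measured", "known", "first", "only" and "open" are said of these compounds alone.

Measured compounds:
compound 1 `CC(C)C[C@H](N)CN(C(=O)[C@@H]1C[C@H]1c1ccccc1)c1ccc(-c2ccccc2)cc1`, 880 nM
compound 2 `CCC(C)CNCCN(C(=O)[C@@H]1C[C@H]1c1ccccc1)c1ccc(-c2ccccc2)cc1`, 4.7 nM
compound 3 `CC[C@H](C)[C@H](N)CN(C(=O)[C@@H]1C[C@H]1c1ccc(Cl)cc1)c1ccc(-c2ccccc2)cc1`, 4300 nM

In a functional assay for agonist activity at G protein-coupled receptor 88 (Homo sapiens), read by HTRF and cAMP accumulation (on this read-out lower numbers stand for an effect already at smaller amounts and higher numbers for an effect only at larger amounts of compound), compound 3 gives the highest number of the three; compound 1 is nearest and compound 2 furthest. Compound 4 `CC[C@H](C)[C@H](N)CN(C(=O)[C@@H]1C[C@H]1c1ccccn1)c1ccc(-c2ccccc2)cc1` differs from compound 3 in one place: pyridin-2-yl in place of 4-chlorophenyl on a saturated ring carbon. For the measured compounds named here, the only measured step, a 190-fold lower number from compound 1 to compound 2 (2.27 log units; beyond the scatter), changes the amine-bearing chain and not the aryl group on the three-membered ring, so nothing measured bears directly on this exchange. Without a matching precedent, compound 4 is expected to stay close to compound 3, with the step of a 1.4-fold higher number from compound 3 to compound 4 (0.14 log units; within the scatter) estimated as a modest rise that could fall inside the scatter. Compound 4 is therefore expected to give about 6000 nM in this assay, within a range of 1500 nM to 25000 nM.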

Compound 4, half-maximal effective concentration: 130 nM
Beside the measured number, compound 4's estimate is 46-fold (1.66 log units) above it; measured number below the stated range.
By their numbers in this assay, from the lowest: compound 2; then compound 4; then compound 1; then compound 3.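

In this assay the exchange of 4-chlorophenyl for pyridin-2-yl on a saturated ring carbon gives a 33-fold lower number from compound 3 to compound 4 (1.52 log units; beyond the scatter) and so shows that this aryl group can shift the number strongly. For the compounds shown here, the only earlier step changed the amine-bearing chain, so the amine-bearing chain is no longer the only place seen to matter. Nothing measured here explains why this exchange has so large an effect. On these data alone, whether pyridin-3-yl or pyridin-4-yl would give a similar result remains open. So does the outcome of pairing pyridin-2-yl with the (2-methylbutyl)amino chain of compound 2.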